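A few compounds are considered here, and "the series" means these few. Any claim that something is new, unique, unknown or untested is made for them only; others in the source may bear on it.

Measured so far in a functional assay on K562 cells (Homo sapiens) for cytotoxicity, read by MTT assay, with a stated time of 24 h; on this read-out lower numbers stand for stronger inhibition and higher numbers for weaker inhibition:
compound 1, `COc1cc(-c2ccnc(Nc3cc(NS(=O)(=O)c4ccc(-c5ccccc5)cc4)ccc3C)n2)cc(OC)c1OC`: 5600 nM
compound 2, `COc1ccc(S(=O)(=O)Nc2ccc(C)c(Nc3nccc(-c4cc(OC)c(OC)c(OC)c4)n3)c2)cc1`: 9120 nM

Compound 2 holds the highest of the two numbers; its nearest neighbour is compound 1, and the step of a 1.6-fold higher number from compound 1 to compound 2 (0.21 log units; within the scatter) stays within the scatter, so no order between the two compounds can be drawn from these figures.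

Compound 3, `COc1ccc(S(=O)(=O)Nc2ccc(C)c(Nc3nccc(-c4cc(OC)c(OC)c(OC)c4)n3)c2)cc1OC`, is not yet measured. It differs from compound 2 by methoxy in place of hydrogen on an aromatic carbon. Within the data shown here, only one measured step touches the same ring, namely a 1.6-fold higher number from compound 1 to compound 2 (0.21 log units; within the scatter), in which a methoxy took the place of a phenyl; that step did not leave the scatter. Among the measured compounds shown here, no measured step shows a methoxy entering in place of hydrogen anywhere, so nothing in hand points to a shift in either direction. Given that a 1.6-fold higher number from compound 1 to compound 2 (0.21 log units; within the scatter) remained within the scatter, the expected step of a 1.0-fold lower number from compound 2 to compound 3 (0.01 log units; within the scatter) is likewise taken to be no larger than the scatter allows. For compound 3 the estimate in this assay is 9000 nM, with a range from 4000 nM to 20000 nM.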

Compound 3, half-maximal inhibitory concentration: 8570 nM
The estimate for compound 3 lay 1.1-fold (0.02 log units) above the measured number; low and high end bracket the measured number.
By their numbers in this assay, from the lowest: compounds 1, 3 and 2 (each within the scatter of the next).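

In this assay, among these compounds, the change from 4-methoxyphenyl to 3,4-dimethoxyphenyl gives a 1.1-fold lower number from compound 2 to compound 3 (0.03 log units; within the scatter), the only measured case of a methoxy entering in place of hydrogen; at this place on the ring, ortho to a methoxy group and meta to a large group, the added methoxy produces no step that leaves the scatter. The step of a 1.5-fold higher number from compound 1 to compound 3 (0.18 log units; within the scatter), with 3,4-dimethoxyphenyl in place of 4-phenylphenyl on the sulfonyl sulfur, also stays within the scatter, so that, together with a 1.6-fold higher number from compound 1 to compound 2 (0.21 log units; within the scatter), no order can be drawn among the three groups on the sulfonyl sulfur. No measurement is available that would tie this result to any property of the groups.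

On these data alone, it remains open whether an amine or a carboxylic acid at this place on the ring, or a longer chain such as ethoxy in place of the added methoxy, would give a step beyond the scatter. As far as these compounds go, it also remains open whether the same methoxy would behave alike at another place on this ring or on a compound with a different core.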